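This account rests on a few compounds, and the source may have more. Where it says the series, first, only, none or still open, it means among the compounds named here.

Among the measured compounds shown here, in an assay on isolated protein for inhibition of long-chain fatty acid transport protein 1 (Homo sapiens) (on this read-out lower numbers stand for stronger inhibition and higher numbers for weaker inhibition), compound 2 `CCn1c(CNc2ccccc2)nnc1SCc1nc2cc(C(=O)C(C)C)ccc2o1` gives 600 nM, the only number among the values shown. Compound 1 `CCn1c(CNc2ccccc2)nnc1SCC(=O)Nc1ccc(Cl)cc1` sits at the limit of this assay, > 1000 nM, which is a limit and not a number (the limit of > 1000 nM in this assay, at which 1 of the 2 values shown sits). Compound 3 `CCC(O)c1ccc2oc(CSc3nnc(CNc4ccccc4)n3CC)nc2c1` differs from compound 2 by 1-hydroxypropyl in place of isopropylcarbonyl on an aromatic carbon. For the measured compounds named here, no measured pair shows what this kind of change does, so the expected step of a 1.5-fold higher number from compound 2 to compound 3 (0.18 log units; within the scatter) is set small, pointing toward weaker inhibition but not clearly beyond the usual scatter. For compound 3 the estimate in this assay is 900 nM, with a range from 300 nM to 3000 nM.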

Compound 3, half-maximal inhibitory concentration: > 1000 nM
Compound 3 ended at the assay's limit (the forecaster's own chance of this, stated with the estimate: 40%); middle value at least 1.1-fold (0.04 log units) away from the limit.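

Compound 3 sits at a limit of the assay, which is not a number. Placing 1-hydroxypropyl instead of isopropylcarbonyl on this aromatic carbon gives an at least 1.6-fold higher number from compound 2 to compound 3 (0.22 log units; that floor lies within the scatter) and so brings no gain in inhibition, though that floor alone does not establish a real loss. The true size of the step cannot be read because of the assay's limit: the limit of > 1000 nM in this assay, at which 2 of the 3 values shown sit.

From the compounds shown here alone, whether an amine or a carboxylic acid on this aromatic carbon would match compound 2 stays open. So does the effect of a longer chain carrying the carbonyl.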